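Fluoro in Place of Iodo: an Expected Cytotoxicity Value

The compounds below may be only part of what the source reports. "The series", "measured", "known", "first", "only" and "open" are said of these compounds alone.

Compound 1 `C/C(=N\NC(=S)Nc1cccc(I)c1)c1ccccn1` gives 84 nM in a functional assay on U-87MG ATCC cells (Homo sapiens) for cytotoxicity, read by MTT assay, with a stated time of 48 h; a higher number here means a weaker inhibitor, a lower number a stronger inhibitor. Compound 2 `C/C(=N/NC(=S)Nc1cccc([N+](=O)[O-])c1)c1ccccn1` gives 69 nM in this assay, and compound 3 `C/C(=N/NC(=S)Nc1cccc(I)c1)c1ccccn1` gives 84 nM in this assay. Compound 3 therefore stands level with compound 1 at the digits shown, the two together forming the highest of the three numbers, with compound 2 furthest away by a margin that stays within the scatter. The step of no change at the digits printed from compound 1 to compound 3 (within the scatter) shows no change, as the two structures differ only in the drawn configuration (the fact that compounds 1 and 3 differ only in the configuration as drawn). The step of a 1.2-fold higher number from compound 2 to compound 3 (0.09 log units; within the scatter) likewise stays within the scatter.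

Compound 4 `C/C(=N/NC(=S)Nc1cccc(F)c1)c1ccccn1` differs from compound 3 by fluoro in place of iodo on an aromatic carbon. The measured step that bears on this change is a 1.2-fold higher number from compound 2 to compound 3 (0.09 log units; within the scatter), where exchanging one group for another on the same aromatic carbon moved the number by an amount within the scatter. On that basis the step of a 1.2-fold higher number from compound 3 to compound 4 (0.08 log units; within the scatter) is expected to stay within the scatter, with no direction to be read from it. Compound 4 is thus expected to give about 100 nM in this assay, within a range from 45 nM to 250 nM.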

Compound 4, half-maximal inhibitory concentration: 18 nM
Compound 4: the middle estimate sits 5.6-fold (0.74 log units) above what was measured; the measured number lies below the stated range.
By their numbers in this assay, from the lowest: compound 4; then compounds 2, 1 and 3 (each within the scatter of the next).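

At the aromatic carbon meta to a large group, the choice of group does move the number in this assay: fluoro in place of iodo gives a clear drop (a 4.7-fold lower number from compound 3 to compound 4 (0.67 log units; beyond the scatter)), and fluoro in place of nitro gives another (a 3.8-fold lower number from compound 2 to compound 4 (0.58 log units; beyond the scatter)). The earlier compounds carried only iodo and nitro on this carbon, and those two stood within the scatter of each other, so the position had not yet shown any response to a change of group. No measured property of these compounds bears on this result, so the drop stays unexplained here.

As far as these compounds go, what remains open is whether the lower number belongs to fluoro alone or would also appear with chloro, methyl or an amine on this same carbon. Configuration is seen only for the iodo pair, so whether the other configuration of compound 4 would keep its number is also open.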